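The source may hold more compounds than are shown below. What is called first, only, known or untested is meant among the compounds shown, and "the series" means these compounds.

Measured so far:
compound 1 `COc1ncnc2c1c(-c1ccsc1)cn2[C@@H]1O[C@H](CO)[C@@H](O)[C@H]1O` — 90 nM in a functional assay on K562 cells (Homo sapiens), read by MTT assay, with a stated time of 72 h; a higher number here means a weaker inhibitor, a lower number a stronger inhibitor
compound 2 `CN(C)c1ncnc2c1c(-c1ccsc1)cn2[C@@H]1O[C@H](CO)[C@@H](O)[C@H]1O` — 530 nM in this assay

For the measured compounds named here, compound 1 holds the lowest of the two numbers in this assay; its only neighbour lies at a 5.9-fold higher number from compound 1 to compound 2 (0.77 log units; beyond the scatter), a step beyond the scatter, brought about by dimethylamino in place of methoxy on an aromatic carbon. Compound 3 `COc1ncnc2c1c(-c1ccccc1)cn2[C@@H]1O[C@H](CO)[C@@H](O)[C@H]1O` is not yet measured. It differs from compound 1 as follows: phenyl in place of thiophen-3-yl on an aromatic carbon. Going by the values given here, no measured step touches the group at this position; the single step in hand, methoxy to dimethylamino, alters another part of the shared core and carries no information on the present exchange. With nothing to anchor a direction, the expectation for compound 3 is a number close to that of compound 1, with a 1.3-fold higher number from compound 1 to compound 3 (0.12 log units; within the scatter) expected to stay within the scatter. Compound 3 is estimated at 120 nM, range 40 nM to 400 nM.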

Compound 3, half-maximal inhibitory concentration: > 20000 nM
Compound 3 was reported as a limit; the forecaster's own chance of this, stated with the estimate: 3%; middle value at least 160-fold (2.22 log units) away from the limit.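

At this aromatic carbon, the aryl group decides whether the compound registers at all in this assay: phenyl in place of thiophen-3-yl gives an at least 220-fold higher number from compound 1 to compound 3 (2.34 log units; beyond the scatter). The earlier exchange of methoxy for dimethylamino, a 5.9-fold higher number from compound 1 to compound 2 (0.77 log units; beyond the scatter), is the smaller of the two steps from compound 1, so this position shows a far sharper dependence on its group than the earlier pair could reveal. The value for compound 3 is a limit of the assay, not a number: the limit of > 20000 nM in this assay, at which 1 of the 3 values shown sits.

The compounds shown do not separate the change from a five-membered to a six-membered aromatic ring from the loss of sulfur, and they leave open how furan-3-yl, thiophen-2-yl or pyridin-3-yl would read at this position. Also open, as far as these compounds go, is whether phenyl gives the same result with dimethylamino on the shared core.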